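The source may hold more compounds than are shown below. What is called first, only, known or untested is meant among the compounds shown, and "the series" means these compounds.

Of the compounds shown here, three of one shared core have been tested in a functional assay on SF-295 cells (Homo sapiens) for inhibition, read by sulforhodamine B assay, with a stated time of 48 h, tested at 100 uM; on this read-out lower numbers stand for a stronger effect and higher numbers for a weaker effect at the one concentration tested. Compound 1 `O=C(Nc1cccc(-n2cc(-c3ccncc3)c(-c3cc(O)cc(Cl)c3)n2)c1)Nc1ccc(Cl)c(C(F)(F)F)c1` gives -80%. Compound 2 `COc1cc(Cl)cc(-c2nn(-c3cccc(NC(=O)Nc4ccc(Cl)c(C(F)(F)F)c4)c3)cc2-c2ccncc2)c1` gives -82%, which is the lowest of the three numbers; its nearest neighbour is compound 1, and the step of a number 2 percentage points lower from compound 1 to compound 2 (within the scatter) lies within the scatter, so the two cannot be told apart. Compound 3 `COc1cc(Cl)cc(-c2nn(-c3cccc(NC(=O)Nc4cc(C(F)(F)F)cc(C(F)(F)F)c4)c3)cc2-c2ccncc2)c1` gives -63%, a number higher than that of compound 2 and beyond the scatter, so compound 3 shows a weaker effect in this assay.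

The compound still to be measured is compound 4 `COc1cc(Cl)cc(-c2nn(-c3cccc(NC(=O)c4cccc(C(F)(F)F)c4)c3)cc2-c2ccncc2)c1`. It differs from compound 2 in one place: 3-(trifluoromethyl)phenyl in place of (4-chloro-3-(trifluoromethyl)phenyl)amino on a carbonyl carbon. Going by the values given here, no measured step covers this change; the only measured step, from compound 1 to compound 2, touches the oxygen on the other end of the molecule. The values of compound 2 and compound 3 show that changing the groups on this outer ring can move the read-out well beyond the scatter. The expected step of a number 37 percentage points higher from compound 2 to compound 4 (beyond the scatter) is therefore towards a weaker effect, that is a higher number, with wide uncertainty. For compound 4 the estimated value in this assay is -45%, within a range from -80% to -5%.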

Compound 4, a percentage reported as activity, at one concentration (the size of the read-out at that concentration, not a potency): 35%
Compound 4: the middle estimate sits 80 percentage points below what was measured; the measured number lies above the stated range.
By their numbers in this assay, from the lowest: compounds 2 and 1 (each within the scatter of the next); then compound 3; then compound 4.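

In this assay, putting 3-(trifluoromethyl)phenyl in place of (4-chloro-3-(trifluoromethyl)phenyl)amino on the carbonyl carbon gives a number 117 percentage points higher from compound 2 to compound 4 (beyond the scatter), and the number crosses from below zero to above zero. This single change therefore moves the read-out far more than the hydroxy-to-methoxy step on the other end of the molecule, so the group on this carbonyl carbon has a large bearing on the result. The group that leaves has a nitrogen, a chlorine and a hydrogen-bond donor that the entering group lacks, while the aromatic ring and the trifluoromethyl group remain, and no measurement shown here accounts for the size of the step.

The compounds shown leave open whether the nitrogen, the chlorine or both together carry this step, since both disappear in the same change. (3-(Trifluoromethyl)phenyl)amino and 4-chloro-3-(trifluoromethyl)phenyl on the same carbonyl carbon, each keeping one of the two, would pull these contributions apart.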